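The source may report more compounds than this note shows. Statements on the series, on what has been measured and on what is new or still open speak of the compounds shown alone.

Compound 1 `Nc1ccccc1NC(=O)c1ccc(Cn2cnc3c(Nc4ccc(-c5ccccn5)cc4)nc(Cl)nc32)cc1`, 73.7%; compound 2 `Nc1ccccc1NC(=O)c1ccc(Cn2cnc3c(Nc4cccc(OC(F)(F)F)c4)nc(Cl)nc32)cc1`, 46.6%; compound 3 `CC(C)n1cnc2c(Nc3ccccc3)nc(NCOCc3ccc(/C=C/C(=O)Nc4ccccc4N)cc3)nc21`, 41.7%.

In a functional assay on HCT-116 cells (Homo sapiens) for antiproliferative activity, read by CCK-8 assay, with a stated time of 72 h, tested at 8 uM (on this read-out lower numbers stand for a weaker effect and higher numbers for a stronger effect at the one concentration tested), compound 2 stands second highest of the three, with compound 3 within the scatter of it and compound 1 beyond. Compound 4 `CC1CCN(c2nc(Cl)nc3c2ncn3Cc2ccc(C(=O)Nc3ccccc3N)cc2)CC1` differs from compound 2 in one place: 4-methylpiperidin-1-yl in place of (3-(trifluoromethoxy)phenyl)amino on an aromatic carbon. For the measured compounds named here, the only measured step at this position, a number 27.1 percentage points lower from compound 1 to compound 2 (beyond the scatter), changed a substituted phenylamino group for another and was modest. Going by the values given here, no measured step exchanges an arylamino group for a saturated amine such as 4-methylpiperidin-1-yl, so the direction is uncertain; a step of about that size, downward or none beyond the scatter, is expected. Compound 4 is therefore estimated at 40%, within 18% to 62%, an expected step of a number 6.6 percentage points lower from compound 2 to compound 4 (within the scatter).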

Compound 4, a percentage reported as inhibition, at one concentration (the size of the read-out at that concentration, not a potency): 78.6%
The estimate for compound 4 lay 38.6 percentage points below the measured number; the measured number lies above the stated range.
By their numbers in this assay, from the lowest: compounds 3 and 2 (each within the scatter of the next); then compounds 1 and 4 (each within the scatter of the next).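

In this assay, this position does not depend on an arylamino group: 4-methylpiperidin-1-yl, a non-aromatic ring without a hydrogen-bond donor, gives a number 32 percentage points higher from compound 2 to compound 4 (beyond the scatter). Compound 4 thereby stands within the scatter of compound 1 at 73.7%, so the saturated ring does as well here as the 4-(pyridin-2-yl)phenyl amino group. Nothing available explains the size of this step. The compounds shown leave open whether the methyl group of 4-methylpiperidin-1-yl matters, and whether a plain piperidine or a morpholine would hold the number at this position.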